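This account rests on a few compounds, and the source may have more. Where it says the series, first, only, none or still open, it means among the compounds named here.

Measured compounds:
Compound 1, `O=C(NC1CCCCC1)c1ccccc1[Se][Se]c1ccccc1C(=O)NC1CCCCC1`, gives > 40000 nM in a functional assay on DU-145 cells (Homo sapiens) for cytotoxicity, read by sulforhodamine B assay, with a stated time of 24 h (on this read-out higher numbers stand for weaker inhibition and lower numbers for stronger inhibition), which is a limit of the assay rather than a number.
Compound 2, `CC(C)CCNC(=O)c1ccccc1[Se][Se]c1ccccc1C(=O)NCCC(C)C`, gives > 40000 nM in this assay, again a limit and not a number.
Compound 3, `CC(C)CCn1[se]c2ccccc2c1=O`, gives 30400 nM in this assay.

Compound 3 is the only one of the three that returns an actual number; the other two sit at the limit of > 40000 nM in this assay, at which 2 of the 3 values shown sit. Going by the values given here, compound 3 therefore stands alone among the measured values, and there is no pair of measured compounds differing in a single place from which the size of any step could be read off.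

Compound 4, `CCCCn1[se]c2ccccc2c1=O`, is not yet measured. It differs from compound 3 by hydrogen in place of methyl on a saturated chain carbon bound to two saturated chain carbons. Among the compounds with values here, no measured pair in this set shows what such a change does in this assay, so the expectation rests on the value of compound 3 alone. Because compound 3 gives 30400 nM, there is a real chance that compound 4 returns no actual number at all. Such an outcome would place compound 4 where compound 1 and compound 2 already sit, at the limit of > 40000 nM in this assay, at which 2 of the 3 values shown sit. The step from compound 3 to compound 4 is expected to be small, a 1.2-fold higher number from compound 3 to compound 4 (0.06 log units; within the scatter), and not beyond the usual scatter in either direction. Compound 4 is therefore estimated at 35000 nM, with a range from 15000 nM to 80000 nM.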

Compound 4, half-maximal inhibitory concentration: 20800 nM
Compound 4: middle estimate off by 1.7-fold (0.23 log units), on the high side; low and high end bracket the measured number.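

Going by these compounds alone, the step of a 1.5-fold lower number from compound 3 to compound 4 (0.16 log units; within the scatter) in this assay is the first in this set that can be read, and it belongs to the change from isopentyl to butyl, with hydrogen in place of methyl on a saturated chain carbon bound to two saturated chain carbons. At this place, then, the methyl gives way to hydrogen without a difference that this read-out can separate from the scatter of repeated measurements, and compound 3 and compound 4 must be treated as equal here, a finding that rests on this single pair. Compound 4 also gives an actual number and does not join compound 1 and compound 2, whose values are limits of the assay and not numbers: the limit of > 40000 nM in this assay, at which 2 of the 4 values shown sit.

The compounds shown leave open whether a longer chain, such as hexyl or octyl, would carry the number beyond the scatter in either direction. They also leave open what an amine or a carboxylic acid at the end of the chain would do in this assay, since one small step says nothing about groups of another kind.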